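Naphthyl Amide Replaces Tetrahydronaphthyl on a Shared Core

The compounds below may be only part of what the source reports. "The series", "measured", "known", "first", "only" and "open" are said of these compounds alone.

In a functional assay on HT-29 cells (Homo sapiens) for cytotoxicity, read by MTT assay, with a stated time of 72 h (a higher number here means a weaker inhibitor, a lower number a stronger inhibitor), compound 3 `CN1[C@@H]2c3[nH]c4ccccc4c3C[C@H]1[C@H](C#N)N1[C@@H](CNC(=O)c3cccc4c3CCCC4)c3[nH]c4ccccc4c3C[C@@H]21` gives 3340 nM, the highest of the three numbers seen so far. Compound 1 `CN1[C@@H]2c3[nH]c4ccccc4c3C[C@H]1[C@H](C#N)N1[C@@H](CNC(=O)c3cccc(C(F)(F)F)c3)c3[nH]c4ccccc4c3C[C@@H]21` gives 140 nM and compound 2 `COc1ccc(C(=O)NC[C@H]2c3[nH]c4ccccc4c3C[C@H]3[C@H]4c5[nH]c6ccccc6c5C[C@@H]([C@H](C#N)N23)N4C)cc1` gives 840 nM; the steps run a 6.0-fold higher number from compound 1 to compound 2 (0.78 log units; beyond the scatter), a 24-fold higher number from compound 1 to compound 3 (1.38 log units; beyond the scatter) and a 4.0-fold higher number from compound 2 to compound 3 (0.60 log units; beyond the scatter), so every exchange of the group on the carbonyl carbon moved this assay beyond the scatter. Compound 4 `CN1[C@@H]2c3[nH]c4ccccc4c3C[C@H]1[C@H](C#N)N1[C@@H](CNC(=O)c3ccc4ccccc4c3)c3[nH]c4ccccc4c3C[C@@H]21` differs from compound 3 in one place: naphthalen-2-yl in place of 1,2,3,4-tetrahydronaphthalen-5-yl on a carbonyl carbon. Among the compounds with values here, no measured step makes exactly this exchange, but both replacements of the 1,2,3,4-tetrahydronaphthalen-5-yl group seen so far, read backwards from compound 3, gave lower numbers, once modest and once large. A downward step of modest size, lying between those two, is therefore expected, with wide uncertainty since neither comparison uses the naphthalen-2-yl group itself. Compound 4 is estimated at 600 nM, with a range from 150 nM to 2500 nM, meaning an expected step of a 5.6-fold lower number from compound 3 to compound 4 (0.75 log units; beyond the scatter).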

Compound 4, half-maximal inhibitory concentration: 4940 nM
Compound 4: the middle estimate sits 8.2-fold (0.92 log units) below what was measured, outside the stated range (above it).
By their numbers in this assay, from the lowest: compound 1; then compound 2; then compounds 3 and 4 (each within the scatter of the next).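

In this assay, trading the non-aromatic ring of the 1,2,3,4-tetrahydronaphthalen-5-yl group for the second aromatic ring of naphthalen-2-yl, at an equal count of heavy atoms, gives a 1.5-fold higher number from compound 3 to compound 4 (0.17 log units; within the scatter) and so leaves the pair indistinguishable. Within the data shown here, this is the first exchange on the carbonyl carbon that stays within the scatter, as all earlier exchanges there went beyond it. The naphthalen-2-yl group also stands apart from the two single-ring groups, with a 5.9-fold higher number from compound 2 to compound 4 (0.77 log units; beyond the scatter) and a 35-fold higher number from compound 1 to compound 4 (1.55 log units; beyond the scatter) in the same direction as the steps to compound 3.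

No measurement at hand bears on why these numbers fall as they do. As far as these compounds go, whether an unsubstituted phenyl group, or a phenyl group carrying an amine or a carboxylic acid, would sit nearer compound 1 or nearer compound 3 and compound 4 remains open.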